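The compounds below may be only part of what the source reports. "The series", "measured", "known", "first", "only" and "open" are said of these compounds alone.

Measured in a functional assay on GBM cells (Homo sapiens), read by neutral red uptake, with a stated time of 48 h; on this read-out higher numbers stand for weaker inhibition and lower numbers for stronger inhibition:
- compound 1 `Nc1nccc(-c2c[nH]c3nc(Br)ccc23)n1`: > 20000 nM (a limit)
- compound 2 `COCCOc1ccnc2[nH]cc(-c3ccnc(N)n3)c12`: > 20000 nM (a limit)

In this assay compound 2 gives > 20000 nM, which is a limit and not a number. Going by the values given here, the measured series so far stands at the limit of > 20000 nM in this assay, at which 2 of the 2 values shown sit, so it offers no numerical step to work from.

Compound 3 `CCCOc1ccnc2[nH]cc(-c3ccnc(N)n3)c12` differs from compound 2 in a single place, with methyl in place of methoxy on a saturated chain carbon, two bonds along the chain from an oxygen on an aromatic ring, which turns 2-methoxyethoxy into propoxy: methyl in place of methoxy on a saturated chain carbon, two bonds along the chain from an oxygen on an aromatic ring.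

Among the compounds with values here, with no measured step as a guide, the direction is a tentative expectation: some shift towards stronger inhibition in this assay, of uncertain size, with a result at the limit again still quite possible. The expected change is an at least 10-fold lower number from compound 2 to compound 3 (1.00 log units; beyond the scatter). For compound 3 the estimated value is 2000 nM, with an expected range of 50 nM to 20000 nM.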

Compound 3, half-maximal inhibitory concentration: 80 nM
The estimate for compound 3 lay 25-fold (1.40 log units) above the measured number; low and high end bracket the measured number.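

In this assay, this place on the chain is shown to matter: methyl in place of methoxy, which turns 2-methoxyethoxy into propoxy, gives an at least 250-fold lower number from compound 2 to compound 3 (2.39 log units; beyond the scatter), the first step in the series that can be read at all. Compound 2 gives > 20000 nM, which is a limit. The step therefore has an open upper end, and compound 3, at 80 nM, holds the only value shown that is a number: the limit of > 20000 nM in this assay, at which 2 of the 3 values shown sit.

Going by these compounds, whether a longer chain such as butoxy, or an amine or a carboxylic acid in place of the methyl, keeps a value close to that of compound 3 stays open. Also open, on these data alone, is whether methyl in place of methoxy gives a step of this kind on another chain or core, as the change stands in this one pair only.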